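Oxetane in Place of a Trifluoromethylethyl Carbamate Group

This account rests on a few compounds, and the source may have more. Where it says the series, first, only, none or still open, it means among the compounds named here.

Measured compounds in a functional assay on isolated protein for inhibition of Glucose-dependent insulinotropic receptor (Homo sapiens), read by HTRF and cAMP accumulation; on this read-out lower numbers stand for an effect already at smaller amounts and higher numbers for an effect only at larger amounts of compound:
compound 1 `Cc1nc(S(C)(=O)=O)ccc1Oc1ncnc(OC2CCN(C(=O)OC(C)(C)C(F)(F)F)CC2)c1F` gives 6.53 nM
compound 2 `Cc1nc(S(C)(=O)=O)ccc1Oc1ncnc(OC2CCN(C(=O)OC(C)(C)C#N)CC2)c1F` gives 92.9 nM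
compound 3 `Cc1nc(S(C)(=O)=O)ccc1Oc1ncnc(OC2CCN(C(=O)O[C@H](C)C(F)(F)F)CC2)c1F` gives 9.2 nM

Compound 3 sits between the other two. Its nearest neighbour is compound 1, the difference being a 1.4-fold higher number from compound 1 to compound 3 (0.15 log units; within the scatter), which lies within the scatter. Its furthest neighbour is compound 2, with a 10-fold lower number from compound 2 to compound 3 (1.00 log units; beyond the scatter), a step beyond the scatter.

Compound 4 `Cc1nc(S(C)(=O)=O)ccc1Oc1ncnc(OC2CCN(C(=O)OC3(C(F)(F)F)COC3)CC2)c1F` differs from compound 3 in one place: 3-(trifluoromethyl)oxetan-3-yl in place of 1-(trifluoromethyl)ethyl on an oxygen next to a carbonyl group. The trifluoromethyl group is kept, and the methyl on the carbamate carbon is replaced by ring closure into an oxetane. Within the data shown here, two measured steps bear on this. Adding a methyl at that carbon, from compound 1 to compound 3, produced a 1.4-fold higher number from compound 1 to compound 3 (0.15 log units; within the scatter), within the scatter. Exchanging the trifluoromethyl itself for cyano, from compound 1 to compound 2, produced a 14-fold higher number from compound 1 to compound 2 (1.15 log units; beyond the scatter). Since compound 4 keeps the trifluoromethyl and only alters the substitution around it, the step is expected to stay near the scatter, a 1.4-fold higher number from compound 3 to compound 4 (0.15 log units; within the scatter). Compound 4 is therefore estimated at 13 nM, with a range from 4 nM to 45 nM.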

Compound 4, half-maximal effective concentration: 29.3 nM
For compound 4 the middle estimate is 2.3-fold (0.35 log units) below the measured one, within the range that was stated.
By their numbers in this assay, from the lowest: compounds 1 and 3 (each within the scatter of the next); then compound 4; then compound 2.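

At this position, on an oxygen next to a carbonyl group, keeping the trifluoromethyl does not by itself hold the number: the 3-(trifluoromethyl)oxetan-3-yl group gives a 3.2-fold higher number from compound 3 to compound 4 (0.50 log units; beyond the scatter) and a 4.5-fold higher number from compound 1 to compound 4 (0.65 log units; beyond the scatter), whereas the earlier exchange between the two open trifluoromethyl groups gave only a 1.4-fold higher number from compound 1 to compound 3 (0.15 log units; within the scatter). The oxetane still retains part of the advantage over the nitrile-bearing group, with a 3.2-fold lower number from compound 2 to compound 4 (0.50 log units; beyond the scatter), so this four-membered ring places the value between those of the open trifluoromethyl groups and the 1-cyano-1-methylethyl group. Nothing measured here accounts for this shift.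

The compounds shown leave open whether the step follows from the ring closure or from the ring oxygen. A 1-(trifluoromethyl)cyclobutyl group or a 3-methyloxetan-3-yl group at the same place would separate the two.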